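Dropping a Trifluoromethoxy Group: What to Expect

A few compounds are considered here, and "the series" means these few. Any claim that something is new, unique, unknown or untested is made for them only; others in the source may bear on it.

Compound 1 `CC(c1ccc(-c2ccccc2)c(F)c1)c1nnc2n1N=C(c1ccc(Cl)cc1)CS2`: 7800 nM
Compound 2 `CC(C)Cc1ccc(C(C)c2nnc3n2N=C(c2ccc(OC(F)(F)F)cc2)CS3)cc1`: 3000 nM
Compound 3 `COc1ccc2cc(C(C)c3n[nH]c(=S)n3N)ccc2c1`: 20200 nM

All three were tested in a functional assay on HCT-116 cells (Homo sapiens) for inhibition, read by sulforhodamine B assay, with a stated time of 72 h; on this read-out lower numbers stand for stronger inhibition and higher numbers for weaker inhibition. Compound 2 stands at the lowest number of the three; compound 1 is nearest to it and compound 3 furthest, and both gaps lie beyond the usual scatter. Compound 4 `CC(C)Cc1ccc(C(C)c2nnc3n2N=C(c2ccccc2)CS3)cc1` has not been measured. It differs from compound 2 by hydrogen in place of trifluoromethoxy on an aromatic carbon. Among the measured compounds shown here, no measured pair isolates this change, so its size is uncertain; a modest step toward a higher number, at or just beyond the scatter, is expected in this assay. Compound 4 is therefore expected to give about 6000 nM, within 2500 nM to 15000 nM, a step of a 2.0-fold higher number from compound 2 to compound 4 (0.30 log units; within the scatter).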

Compound 4, half-maximal inhibitory concentration: 7600 nM
The estimate for compound 4 lay 1.3-fold (0.10 log units) below the measured number, within the range that was stated.
By their numbers in this assay, from the lowest: compound 2; then compounds 4 and 1 (each within the scatter of the next); then compound 3.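

Among the compounds shown here, this pair gives the first direct reading at this position: with hydrogen in place of trifluoromethoxy, para to a large group, there is a 2.5-fold higher number from compound 2 to compound 4 (0.40 log units; beyond the scatter) and the change is modest but measurable. The earlier compounds shown here differ from one another in several places, so none of them could isolate this single change. As far as these compounds go, whether a fluorine atom or an amine at the same place would sit nearer compound 2 or compound 4 remains open. Nothing measured here explains the size of the step.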